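Replacing the 4-(dimethylamino)butoxy group of compound 3

The source may report more compounds than this note shows. Statements on the series, on what has been measured and on what is new or still open speak of the compounds shown alone.

Among the compounds with values here, the compounds measured so far in a physicochemical assay for solubility, at pH 7.4 (on this read-out lower numbers stand for lower solubility and higher numbers for higher solubility), are these.
- Compound 1 `CCCCNc1nc(N)c2nc(O)n(Cc3ccc(C)cc3)c2n1` gives < 1000 ug/mL as a limit of the assay, not a number
- Compound 2 `CCCCNc1nc(N)c2[nH]c(=O)n(Cc3ccc(N(C)C)cc3)c2n1` gives 98000 ug/mL as a number
- Compound 3 `CCCCNc1nc(N)c2[nH]c(=O)n(Cc3ccc(OCCCCN(C)C)nc3)c2n1` gives 350000 ug/mL as a number

Within the data shown here, only two of the three compounds have a number. Compound 3 (350000 ug/mL) holds the higher of the two, and the gap down to compound 2 (98000 ug/mL) lies beyond the scatter. Compound 1 has only a limit (< 1000 ug/mL), so it cannot be placed exactly.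

Compound 4 `CCCCNc1nc(N)c2[nH]c(=O)n(Cc3ccc(N4CCNCC4)nc3)c2n1` carries piperazin-1-yl in place of 4-(dimethylamino)butoxy on an aromatic carbon, next to the ring nitrogen and para to a large group (piperazin-1-yl in place of 4-(dimethylamino)butoxy on an aromatic carbon). Among the measured compounds shown here, no pair of measured compounds differs in one place only, so this change has no direct precedent. For the measured compounds named here, the numbers of compound 2 (98000 ug/mL) and compound 3 (350000 ug/mL) are the only guide, and the expected value is placed between them. The expected step is a modest fall (a 2.2-fold lower number from compound 3 to compound 4 (0.34 log units; beyond the scatter)), only slightly beyond the scatter, and its direction is uncertain. In this assay compound 4 is estimated at 160000 ug/mL with an expected range from 40000 ug/mL to 600000 ug/mL as its span.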

Compound 4, solubility: 63000 ug/mL
Compound 4: middle estimate off by 2.5-fold (0.40 log units), on the high side; low and high end bracket the measured number.
By their numbers in this assay, from the lowest: compounds 4 and 2 (each within the scatter of the next); then compound 3. At a limit, below all of these: compound 1.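

Within the data shown here, this result gives the first comparison in one place in this assay: piperazin-1-yl in place of 4-(dimethylamino)butoxy, on an aromatic carbon next to the ring nitrogen, brings a 5.6-fold lower number from compound 3 to compound 4 (0.74 log units; beyond the scatter). The step is modest but beyond the scatter, so the number does depend on which of these two groups sits at this carbon, and with these two groups the direction is downward. The change swaps an open chain without a ring for a six-membered non-aromatic ring that has a hydrogen-bond donor and fewer heavy atoms, and nothing measured here gives a cause for the step.

Which of these differences goes with the lower number stays open, as a single step changes the ring, the donor and the size together. Also open, from the compounds shown here alone, is how morpholin-4-yl, 4-methylpiperazin-1-yl or a shorter chain ending in an amine would read at this carbon in this assay, and such groups would show whether the step follows the ring, the free amine hydrogen or the length of the chain.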